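The source may report more compounds than this note shows. Statements on the series, on what has been measured and on what is new or still open speak of the compounds shown alone.

Working notes on a series built on a shared core. Compound 1 `COc1cc(Nc2nc3ccccc3nc2S(=O)(=O)c2ccccc2)cc(OC)c1` gives 50 nM in a functional assay on HL-60 cells (Homo sapiens) for cytotoxicity, read by MTT assay, with a stated time of 72 h; on this read-out higher numbers stand for weaker inhibition and lower numbers for stronger inhibition. Compound 2 `COc1cc(Nc2nc3ccccc3nc2S(=O)(=O)c2ccc(C)cc2)cc(OC)c1` gives 20 nM in this assay, and compound 3 `Cc1ccc(S(=O)(=O)c2nc3ccccc3nc2Nc2cccc(O)c2)cc1` gives 400 nM. Among these three numbers compound 2 stands at the lowest, with compound 1 the nearest and compound 3 the furthest. The two measured steps are a 2.5-fold lower number from compound 1 to compound 2 (0.40 log units; beyond the scatter), a methyl in place of hydrogen on an aromatic carbon, and a 20-fold higher number from compound 2 to compound 3 (1.30 log units; beyond the scatter), a 3-hydroxyphenyl in place of 3,5-dimethoxyphenyl on a nitrogen on an aromatic ring.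

Compound 4 `COc1cc(Nc2nc3ccccc3nc2S(=O)(=O)c2ccc(Br)cc2)cc(OC)c1` awaits measurement. The change from compound 2 to compound 4 is bromo in place of methyl on an aromatic carbon. Of the measured steps only a 2.5-fold lower number from compound 1 to compound 2 (0.40 log units; beyond the scatter) concerns the same aromatic carbon, and it was modest; a 20-fold higher number from compound 2 to compound 3 (1.30 log units; beyond the scatter) alters a different part of the molecule and does not bear on the change. Among the compounds with values here, no measured compound carries a halogen at this carbon, so the direction is open. A small step in this assay, in either direction or none beyond the scatter, is therefore expected, and the estimate is written as a 1.5-fold higher number from compound 2 to compound 4 (0.18 log units; within the scatter). Compound 4 is expected to give 30 nM in this assay, with a range from 10 nM to 90 nM.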

Compound 4, half-maximal inhibitory concentration: 2540 nM
The estimate for compound 4 lay 85-fold (1.93 log units) below the measured number; the whole stated range lies below it.
By their numbers in this assay, from the lowest: compound 2; then compound 1; then compound 3; then compound 4.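

In this assay the change from 4-methylphenyl to 4-bromophenyl gives a 130-fold higher number from compound 2 to compound 4 (2.10 log units; beyond the scatter) and is larger than the step on the nitrogen, a 20-fold higher number from compound 2 to compound 3 (1.30 log units; beyond the scatter). The same carbon also gives a 51-fold higher number from compound 1 to compound 4 (1.71 log units; beyond the scatter) with bromo in place of hydrogen, so this site, which had shown only a modest step with methyl, does not follow one direction from hydrogen: methyl gives a lower number and bromo a much higher one. Methyl and bromo each count one heavy atom with no hydrogen-bond donors or acceptors, so these counts do not separate the two groups, and nothing at hand accounts for the difference between them.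

As far as these compounds go, whether a fluoro or chloro group on this aromatic carbon would stay close to methyl or move with bromo remains open, as does the outcome with a methoxy group or an amine there. From the compounds shown here alone, it is also open whether bromo would give a step of similar size in a compound carrying 3-hydroxyphenyl on the nitrogen.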